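A few compounds are considered here, and "the series" means these few. Any claim that something is new, unique, unknown or untested is made for them only; others in the source may bear on it.

Compound 1 `COC(=O)CNC(=O)CCC(=O)Oc1ccc(C[C@H]2C(=O)OC[C@@H]2Cc2ccc(OC)c(OC)c2)cc1OC` is a lactone bearing a succinate ester chain that ends in a glycine methyl ester amide. In an ADME assay on HeLa cells (Homo sapiens) for cytotoxicity, read by MTT assay (on this read-out higher numbers stand for weaker inhibition and lower numbers for stronger inhibition), compound 1 gives 179000 nM, the lowest of the two numbers recorded. Compound 3 `CCN(CC)C(=O)COc1ccc(C[C@H]2C(=O)OC[C@@H]2Cc2ccc(OC)c(OC)c2)cc1OC` carries a diethylamide instead of that chain and gives 188000 nM, so that a 1.1-fold higher number from compound 1 to compound 3 (0.02 log units; within the scatter). Compound 2 `COc1ccc(C[C@H]2COC(=O)[C@@H]2Cc2ccc(OCC(=O)Nc3ccccc3)c(OC)c2)cc1OC` carries an anilide on the same oxygen; in this assay compound 2 reaches only the limit >= 600000 nM, which is a limit of the assay and not a number. Accordingly an at least 3.3-fold higher number from compound 1 to compound 2 (0.52 log units; beyond the scatter), and an at least 3.1-fold lower number from compound 2 to compound 3 (0.50 log units; beyond the scatter); the ceiling involved is the limit of >= 600000 nM in this assay, at which 1 of the 3 values shown sits.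

Compound 4 `COC(=O)[C@H](CCSC)NC(=O)CCC(=O)Oc1ccc(C[C@H]2C(=O)OC[C@@H]2Cc2ccc(OC)c(OC)c2)cc1OC` is the compound not yet measured. It differs from compound 1 in one place: 2-(methylsulfanyl)ethyl in place of hydrogen on a saturated chain carbon bound to an amide-type nitrogen and a carbonyl carbon. The succinate ester and the amide are kept, and only a side chain is added on the saturated chain carbon bound to the amide-type nitrogen and the carbonyl carbon. Among the measured compounds shown here, the steps that bear on it are those from compound 1 to compound 3, which stayed within the scatter, and from compound 1 to compound 2, which moved to the limit. Since the chain of compound 1 is retained, the expectation is a step of a 1.2-fold higher number from compound 1 to compound 4 (0.07 log units; within the scatter), not beyond the scatter. Compound 4 is therefore estimated at 210000 nM, between 95000 nM and 480000 nM.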

Compound 4, half-maximal inhibitory concentration: 199000 nM
Beside the measured number, compound 4's estimate is 1.1-fold (0.02 log units) above it; low and high end bracket the measured number.
By their numbers in this assay, from the lowest: compounds 1, 3 and 4 (each within the scatter of the next). At a limit, above all of these: compound 2.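

In this assay, placing 2-(methylsulfanyl)ethyl on the saturated chain carbon bound to an amide-type nitrogen and a carbonyl carbon gives a 1.1-fold higher number from compound 1 to compound 4 (0.05 log units; within the scatter), so this carbon carries the added side chain with no step beyond the scatter. The earlier steps shown here exchanged the whole group on the oxygen on an aromatic ring, whereas this one changes the chain of compound 1 from within and keeps the succinate ester, the amide and the methyl ester. Among the four compounds shown, the only steps beyond the scatter still involve compound 2, whose entry is a limit and not a number: the limit of >= 600000 nM in this assay, at which 1 of the 4 values shown sits.

One side chain at this carbon leaves open whether the same holds for an amine, a carboxylic acid, a benzyl group or a longer chain in the same place. Also open, going by these compounds, is what happens at the far end of the chain if a free carboxylic acid replaces the methyl ester, and whether the opposite configuration at this carbon leaves the number within the scatter.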